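Growing the ring-amide substituent: isopropyl to isobutyl

This account rests on a few compounds, and the source may have more. Where it says the series, first, only, none or still open, it means among the compounds named here.

Measured so far:
compound 1, `CC[C@@H]1C(=O)Nc2cnc(Nc3ccc(C(=O)NC4CCN(C)CC4)cc3OC)nc2N1C1CCCC1`: 219 nM
compound 2, `CC[C@@H]1C(=O)N(C(C)C)c2cnc(Nc3ccc(C(=O)NC4CCN(C)CC4)cc3OC)nc2N1C1CCCC1`: 2670 nM

Of the compounds shown here, two with a shared core have been measured in a functional assay on MV4-11 cells (Homo sapiens) for cytotoxicity, read by CellTiter-Blue, with a stated time of 24 h; a higher number here means a weaker inhibitor of growth, a lower number a stronger inhibitor of growth. Compound 1 gives 219 nM in this assay. Compound 2 carries an isopropyl group on the ring amide nitrogen where compound 1 carries hydrogen. In this assay compound 2 gives 2670 nM. Going by the values given here, of the two numbers, compound 2 stands at the higher one; the single measured step, a 12-fold higher number from compound 1 to compound 2 (1.09 log units; beyond the scatter), shows that replacing hydrogen with isopropyl at that nitrogen in this assay raised the number well beyond the scatter.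

Compound 3, `CC[C@@H]1C(=O)N(CC(C)C)c2cnc(Nc3ccc(C(=O)NC4CCN(C)CC4)cc3OC)nc2N1C1CCCC1`, carries the change (isobutyl in place of isopropyl on an amide-type nitrogen in a ring). Among the compounds with values here, the only measured step bearing on this position is the one from compound 1 to compound 2, which was large; it concerns adding a branched chain to an unsubstituted nitrogen, whereas the move to compound 3 only lengthens an already present chain by one carbon. Compound 3 is therefore expected to sit near compound 2 or somewhat higher, a step of a 1.3-fold higher number from compound 2 to compound 3 (0.12 log units; within the scatter) in this assay. The estimate for compound 3 is 3500 nM, with a range from 1200 nM to 11000 nM.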

Compound 3, concentration for 50% growth inhibition: 2530 nM
For compound 3 the middle estimate is 1.4-fold (0.14 log units) above the measured one; low and high end bracket the measured number.
By their numbers in this assay, from the lowest: compound 1; then compounds 3 and 2 (each within the scatter of the next).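

In this assay, moving from the branched isopropyl to the one-carbon-larger isobutyl on the amide-type nitrogen in the ring gives a 1.1-fold lower number from compound 2 to compound 3 (0.02 log units; within the scatter), so these two groups cannot be told apart at this position. Isobutyl in place of hydrogen at the same nitrogen gives a 12-fold higher number from compound 1 to compound 3 (1.06 log units; beyond the scatter), a large step beyond the scatter, and it resembles the earlier one for isopropyl, a 12-fold higher number from compound 1 to compound 2 (1.09 log units; beyond the scatter), so the higher number is no longer tied to isopropyl alone. Across these three compounds, both groups on this nitrogen give a clearly higher number than the amide hydrogen of compound 1, while the added carbon of isobutyl brings no change that the assay can resolve.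

The compounds shown leave open whether a smaller group such as methyl or ethyl on this nitrogen, or a longer chain ending in an amine or a carboxylic acid, would stay with compound 2 and compound 3 or come closer to compound 1. They also leave open what lies behind the large steps from the amide hydrogen, as no measurement given here bears on that question.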